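This account rests on a few compounds, and the source may have more. Where it says the series, first, only, none or still open, it means among the compounds named here.

Of the compounds shown here, three sharing one core have been tested in a functional assay on HCT-116 cells (Homo sapiens) for inhibition, read by MTT assay, with a stated time of 2 days, tested at 10 uM; on this read-out lower numbers stand for less inhibition of growth and higher numbers for more inhibition of growth at the one concentration tested. Compound 1 `CNC(=O)c1cc(Oc2ccc3nc(NC(=O)c4ccc(Cl)cc4Cl)sc3c2)ccn1` gives 15.1%, compound 2 `CNC(=O)c1cc(Oc2ccc3nc(NC(=O)c4ccc(Cl)cc4)sc3c2)ccn1` gives 27.5%, and compound 3 `CNC(=O)c1cc(Oc2ccc3nc(NC(=O)c4cc(Cl)cc(Cl)c4)sc3c2)ccn1` gives 13.4%, the smallest of the three numbers, with compound 1 within the scatter of it and only compound 2 clearly apart. Among the steps, a number 12.4 percentage points higher from compound 1 to compound 2 (beyond the scatter) and a number 14.1 percentage points lower from compound 2 to compound 3 (beyond the scatter) were both modest, while a number 1.7 percentage points lower from compound 1 to compound 3 (within the scatter). Compound 4 `CNC(=O)c1cc(Oc2ccc3nc(NC(=O)c4cccc(F)n4)sc3c2)ccn1` differs from compound 3 by 6-fluoropyridin-2-yl in place of 3,5-dichlorophenyl on a carbonyl carbon. For the measured compounds named here, no measured step swaps the whole ring, so only the modest size of the chlorine changes serves as a guide. A step of a number 6.6 percentage points higher from compound 3 to compound 4 (within the scatter) is expected, within the scatter or slightly upward. Compound 4 is therefore estimated at 20%, between 5% and 40%.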

Compound 4, percent growth inhibition at one concentration: 10.8%
The estimate for compound 4 lay 9.2 percentage points above the measured number; measured number inside the range.
By their numbers in this assay, from the lowest: compounds 4, 3 and 1 (each within the scatter of the next); then compound 2.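

In this assay, a full change of ring on this carbonyl carbon, from a carbon-only ring to one holding a hetero atom, gives a number 2.6 percentage points lower from compound 3 to compound 4 (within the scatter) and a number 4.3 percentage points lower from compound 1 to compound 4 (within the scatter), so 6-fluoropyridin-2-yl cannot be told apart from either dichlorophenyl group. Only 4-chlorophenyl stays clearly apart, with a number 16.7 percentage points lower from compound 2 to compound 4 (beyond the scatter). Nothing available explains these numbers. On these data alone, the effect of the ring nitrogen without the fluorine remains open, as 2-pyridyl alone is absent from these compounds. So does how a saturated ring such as piperidine on this carbonyl carbon would compare with compound 2 at 27.5%.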